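Working notes: a third analogue in the chlorophenyl series

A few compounds are considered here, and "the series" means these few. Any claim that something is new, unique, unknown or untested is made for them only; others in the source may bear on it.

Compound 1 `O=C(CSC(=S)N[C@H]1CCOC1=O)Nc1ccc(Cl)cc1`: in a functional assay on EC9706 cells (Homo sapiens) for cytotoxicity, read by MTT assay, with a stated time of 72 h (on this read-out lower numbers stand for stronger inhibition and higher numbers for weaker inhibition), compound 1 gives > 128000 nM, which is a limit of the assay.
Compound 2 `O=C(CSC(=S)N[C@H]1CCOC1=O)Nc1ccccc1Cl`: in this assay compound 2 gives > 128000 nM, again a limit.

Compound 2 therefore stands only at a limit on this read-out, and compound 1 stands at the same limit. Going by the values given here, the single measured step that the two limits leave unreadable from compound 1 to compound 2 carries no readable size because the limit of > 128000 nM in this assay, at which 2 of the 2 values shown sit, holds both of its ends. Among the compounds with values here, no measured step gives a direction or a magnitude for any change in this assay.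

Compound 3 `O=C(CSC(=S)N[C@H]1CCOC1=O)Nc1ccc(Cl)cc1Cl` differs from compound 2 by chloro in place of hydrogen on an aromatic carbon. Nothing measured bears on this change. In the absence of any readable step, compound 3 is expected to remain near the limit, with an estimate of 128000 nM and a range from 20000 nM to 500000 nM. This estimate corresponds to an expected step of a number no higher from compound 2 to compound 3 (the limit leaves the size open), with a high chance that only a limit is reported.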

Compound 3, half-maximal inhibitory concentration: > 128000 nM
Compound 3: a limit, no number; the forecaster's own chance of this, stated with the estimate: 70%; the middle value lies on the limit itself.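

In this assay compound 3 gives > 128000 nM as a limit of the assay. No step among compound 1, compound 2 and compound 3 can be read: the limit of > 128000 nM in this assay, at which 3 of the 3 values shown sit.

The compounds shown leave open whether chloro substitution on the aromatic ring changes this read-out at all.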